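The source may hold more compounds than are shown below. What is called first, only, known or untested is meant among the compounds shown, and "the series" means these compounds.

In a functional assay on the whole organism with Mus musculus as the target (on this read-out lower numbers stand for an effect already at smaller amounts and higher numbers for an effect only at larger amounts of compound), compound 1 `CC(C)=Cc1c(C)c(N)c(C)c2c1OC(C)(C)C2` gives 21.9 mg/kg, compound 2 `Cc1c(C)c2c(c(C)c1N)CC(C)(CSc1ccccc1)O2` gives 24.7 mg/kg and compound 3 `Cc1c(C)c2c(c(C)c1N)CC(C)(CN1CCC(c3ccccc3)CC1)O2` gives 10.4 mg/kg. Compound 2 thus sits at the upper end of the three numbers: compound 1 is within the usual scatter of it, whereas compound 3 lies beyond the scatter at a lower number. Compound 4 `Cc1c(C)c2c(c(C)c1N)CC(C)(CCN(C)C)O2` has not yet been measured in this assay. It differs from compound 2 in one place: (dimethylamino)methyl in place of phenylsulfanyl on a saturated chain carbon bound to a saturated ring carbon. Going by the values given here, no measured pair isolates this change, so the expectation rests on the three values alone. Because compound 3 gives 10.4 mg/kg with the only nitrogen-bearing side chain so far, the expected step is a 1.5-fold lower number from compound 2 to compound 4 (0.19 log units; within the scatter), a shift to a lower number of about the size of the scatter. Compound 4 is therefore estimated at 16 mg/kg, between 7 mg/kg and 35 mg/kg.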

Compound 4, dose for 50% inhibition: 19 mg/kg
The estimate for compound 4 lay 1.2-fold (0.07 log units) below the measured number; the range from low to high includes it.
By their numbers in this assay, from the lowest: compounds 3, 4, 1 and 2 (each within the scatter of the next, the first and the last beyond it).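

In this assay, (dimethylamino)methyl in place of phenylsulfanyl on a saturated chain carbon bound to a saturated ring carbon gives a 1.3-fold lower number from compound 2 to compound 4 (0.11 log units; within the scatter), so this position accepts the loss of the aromatic ring with no step beyond the scatter. Sulfur and the ring can thus both leave this place without a clear shift in the number. Nothing available explains this step.

Open, going by these compounds, is whether a carboxylic acid on this chain carbon would give a step beyond the scatter. A benzyl group would show whether the aromatic ring counts here without sulfur.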